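The source may hold more compounds than are shown below. What is called first, only, known or untested is meant among the compounds shown, and "the series" means these compounds.

Compounds measured so far:
compound 1 `CNC(=O)c1cc(Oc2ccc(C3=NNC(c4ccc(C#N)cc4)C3)cc2)ccn1` with 15000 nM in a functional assay on HepG2 cells (Homo sapiens) for cytotoxicity, read by MTT assay, with a stated time of 72 h; a higher number here means a weaker inhibitor, a lower number a stronger inhibitor
compound 2 `CNC(=O)c1cc(Oc2ccc(C3=NNC(c4ccc(F)cc4Cl)C3)cc2)ccn1` with 11500 nM

Compound 1 gives the highest of the two numbers in this assay, and its nearest neighbour is compound 2, a step of a 1.3-fold lower number from compound 1 to compound 2 (0.12 log units; within the scatter) that stays within the scatter. Compound 3 `CNC(=O)c1cc(Oc2ccc(C3=NNC(c4ccc(Br)cc4)C3)cc2)ccn1` differs from compound 1 by bromo in place of cyano on an aromatic carbon, so the change is bromo in place of cyano on the same aromatic ring that was exchanged wholesale between compound 1 and compound 2. That single measured step is the only one that bears on it: the move to 2-chloro-4-fluorophenyl in place of 4-cyanophenyl left the number essentially where it was. A similar outcome is therefore expected here, with no step beyond the scatter in this assay, so that the estimated step is a 1.2-fold lower number from compound 1 to compound 3 (0.06 log units; within the scatter). For compound 3 the estimate is 13000 nM, with a range from 6000 nM to 30000 nM.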

Compound 3, half-maximal inhibitory concentration: 57600 nM
For compound 3 the middle estimate is 4.4-fold (0.65 log units) below the measured one, and the stated range ends below it.
By their numbers in this assay, from the lowest: compounds 2 and 1 (each within the scatter of the next); then compound 3.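

In this assay, among these compounds, the first measured step at this position that goes beyond the scatter shows that the group on this aromatic ring can shift the number: a 3.8-fold higher number from compound 1 to compound 3 (0.58 log units; beyond the scatter), with bromo in place of cyano on an aromatic carbon para to a large group. The wider exchange gives a similar result, a 5.0-fold higher number from compound 2 to compound 3 (0.70 log units; beyond the scatter), so 4-bromophenyl stands apart from both 4-cyanophenyl and 2-chloro-4-fluorophenyl, which lie within the scatter of each other. No measurement here accounts for this separation.

The compounds shown leave open whether the higher number belongs to bromo alone or would also appear with another single group at that place, such as chloro, methoxy or an amine. They also leave open how a carboxylic acid there would read in this assay.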